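Sulfonyl aryl swap on the methylpiperidinyl-piperidine sulfonamide core

This account rests on a few compounds, and the source may have more. Where it says the series, first, only, none or still open, it means among the compounds named here.

Measured compounds:
compound 1 `CC1CCN(C2CCN(S(=O)(=O)c3cn(C)cn3)CC2)CC1`, > 5000 nM
compound 2 `CC1CCCN(C2CCN(S(=O)(=O)c3ccc(OC(F)F)cc3)CC2)C1`, 105 nM

In a functional assay on DLD-1 cells (Homo sapiens) for antiproliferative activity, read by CellTiter-Glo, with a stated time of 72 h (a lower number here means a stronger inhibitor, a higher number a weaker inhibitor), compound 1 gives > 5000 nM, which is a limit of the assay and not a number. Compound 1 therefore sits at the limit of > 5000 nM in this assay, at which 1 of the 2 values shown sits, so only its lower bound of potency is known. In this assay compound 2 gives 105 nM; compound 2 differs from compound 1 in more than one place, so the two values are noted side by side without drawing a step between them.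

Compound 3 `Cc1nc(Cl)sc1S(=O)(=O)N1CCC(N2CCC(C)CC2)CC1` is not yet measured. It keeps the core of compound 1 and changes only the group on the sulfonyl sulfur: 2-chloro-4-methyl-1,3-thiazol-5-yl in place of 1-methyl-1H-imidazol-4-yl on a sulfonyl sulfur.

For the measured compounds named here, no measured step between two compounds differing in one place is available to calibrate this exchange. With compound 1 known only as a limit, the outcome of the change in this assay is open; an improvement beyond the scatter is expected, though a result that again reports only a limit cannot be excluded. The step of an at least 3.3-fold lower number from compound 1 to compound 3 (0.52 log units; beyond the scatter) is the expected outcome. For compound 3 the estimate in this assay is 1500 nM, in the range 300 nM to 5000 nM.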

Compound 3, half-maximal inhibitory concentration: 1.6 nM
Estimate against measurement, compound 3: 940-fold (2.97 log units) above, outside the stated range (below it).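

With the core of compound 1 held fixed, the group on the sulfonyl sulfur alone accounts for an at least 3100-fold lower number from compound 1 to compound 3 (3.49 log units; beyond the scatter) in this assay, so this position strongly controls activity in the series. The 1-methyl-1H-imidazol-4-yl and 2-chloro-4-methyl-1,3-thiazol-5-yl groups are each one five-membered aromatic ring with the same counts of hetero atoms, hydrogen-bond donors and acceptors and no net charge, so these counts do not separate the inactive group from the active one. For compound 1, > 5000 nM is a limit of the assay, so the printed step gives only a minimum size: the limit of > 5000 nM in this assay, at which 1 of the 3 values shown sits.

The exchange alters the ring atoms, the chlorine and the methyl group together, so the compounds shown do not assign the gain to any one of these features, and an analogue carrying an amine or a nitrile in place of the chlorine would bear directly on that question. Compound 2 differs from compound 3 in more than one place, so the contribution of its 4-(difluoromethoxy)phenyl group relative to the 2-chloro-4-methyl-1,3-thiazol-5-yl group also remains unresolved.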